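Trifluoromethyl for chloro on the aryl-bearing nitrogen

A few compounds are considered here, and "the series" means these few. Any claim that something is new, unique, unknown or untested is made for them only; others in the source may bear on it.

Of the compounds shown here, three on a shared core have been tested in a functional assay on PC-12 cells (Rattus norvegicus) for cytotoxicity, read by MTT assay, with stated times of 2 h and 24 h, tested at 5 uM; on this read-out higher numbers stand for a stronger effect at the one concentration tested and lower numbers for a weaker effect. Compound 1 `Oc1cc(C(F)(F)F)ccc1-c1nc(-c2ccccc2O)n(-c2ccc(Cl)cc2)n1` gives 87.3%, compound 2 `Oc1cc(C(F)(F)F)ccc1-c1nc(-c2ccccc2O)n(-c2ccc(C(F)(F)F)cc2)n1` gives 90.5%, and compound 3 `Oc1cc(C(F)(F)F)ccc1-c1nc(-c2ccccc2O)n(-c2cccc(Cl)c2)n1` gives 92.7%. The cores of compound 1 and compound 3 differ by 3-chlorophenyl in place of 4-chlorophenyl on an aromatic nitrogen, a step of a number 5.4 percentage points higher from compound 1 to compound 3 (within the scatter). Compound 2 differs from compound 1 by trifluoromethyl in place of chloro on an aromatic carbon, a step of a number 3.2 percentage points higher from compound 1 to compound 2 (within the scatter). Compound 4 `Oc1cc(C(F)(F)F)ccc1-c1nc(-c2ccccc2O)n(-c2cccc(C(F)(F)F)c2)n1` awaits measurement; it carries the same kind of change relative to compound 3, (trifluoromethyl in place of chloro on an aromatic carbon), though the place is not identical: para to a large group in compound 1, meta to a large group in compound 3. Because the step of a number 3.2 percentage points higher from compound 1 to compound 2 (within the scatter) stayed within the scatter, compound 4 is expected to show a number 2.3 percentage points higher from compound 3 to compound 4 (within the scatter). Compound 4 is therefore estimated at 95%, between 87% and 100%.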

Compound 4, a percentage reported as activity, at one concentration (the size of the read-out at that concentration, not a potency): 92.2%
Compound 4: the middle estimate sits 2.8 percentage points above what was measured; measured number inside the range.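

In this assay, trifluoromethyl in place of chloro gives a number 0.5 percentage points lower from compound 3 to compound 4 (within the scatter), and the change reads alike on both cores: the same change on two cores in this assay, a number 3.2 percentage points higher (within the scatter) from compound 1 to compound 2 and a number 0.5 percentage points lower (within the scatter) from compound 3 to compound 4, 3.7 percentage points apart, within the scatter of two such steps. The other two new steps, a number 1.7 percentage points higher from compound 2 to compound 4 (within the scatter) and a number 4.9 percentage points higher from compound 1 to compound 4 (within the scatter), also stay within the scatter. The change therefore carries between these two cores without a difference that can be told from the scatter, but neither step can be told from the scatter either, so this does not show that the change has any effect to carry, nor how it would behave on a further core.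

The compounds shown leave open other groups on the phenyl on the aromatic nitrogen, such as an amine or a carboxylic acid. Going by these compounds, the rest of the shared core stays the same throughout, so changes there also remain open.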